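This account rests on a few compounds, and the source may have more. Where it says the series, first, only, none or still open, it means among the compounds named here.

Three compounds share one core, differing only in the group attached on a sulfur. Compound 1 `Cc1nnc(SCc2cc(=O)c3ccccc3o2)s1` carries a 5-methyl-1,3,4-thiadiazol-2-yl group there, compound 2 `Cc1nnc(SCc2cc(=O)c3ccccc3o2)o1` a 5-methyl-1,3,4-oxadiazol-2-yl group, and compound 3 `Nc1nnc(SCc2cc(=O)c3ccccc3o2)s1` a 5-amino-1,3,4-thiadiazol-2-yl group. In a functional assay on MCF7 cells (Homo sapiens) for cytotoxicity, read by MTT assay, with a stated time of 72 h (a higher number here means a weaker inhibitor, a lower number a stronger inhibitor), compound 1 reaches only the limit of the assay, > 25000 nM. Compound 2 likewise gives a limit, > 25000 nM. Compound 3 also stops at a limit, > 25000 nM. All three therefore sit at the limit of > 25000 nM in this assay, at which 3 of the 3 values shown sit, and the steps a step that the two limits leave unreadable from compound 1 to compound 2, a step that the two limits leave unreadable from compound 1 to compound 3 and a step that the two limits leave unreadable from compound 2 to compound 3 cannot be read. Compound 4 `Cc1ccc2oc(CSc3nnc(N)s3)cc(=O)c2c1` differs from compound 3 by methyl in place of hydrogen on an aromatic carbon. Among the measured compounds shown here, since no measured step has a readable size, no direction is expected for a number no higher from compound 3 to compound 4 (the limit leaves the size open), and compound 4 is expected to stay at a limit. The estimate for compound 4 is 25000 nM, within 8000 nM to 60000 nM.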

Compound 4, half-maximal inhibitory concentration: > 25000 nM
Compound 4: no number, only a limit (the forecaster's own chance of this, stated with the estimate: 80%); the middle value sits exactly at the limit.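

Compound 4, like compound 3, stops at a limit, so the change between them gives no readable step: the limit of > 25000 nM in this assay, at which 4 of the 4 values shown sit.

The compounds shown leave open which change to the shared core, if any, would give an actual number in this assay.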